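The compounds below may be only part of what the source reports. "The series", "measured", "known", "first", "only" and "open" are said of these compounds alone.

Among the compounds with values here, in a functional assay on B16-F0 cells (Mus musculus) for inhibition, read by CCK-8 assay, with a stated time of 48 h (on this read-out lower numbers stand for stronger inhibition and higher numbers for weaker inhibition), compound 2 `COc1ccc(-c2cc3nccc(-c4cc(OC)c(OC)c(OC)c4)n3n2)cc1` gives 1410 nM, the higher of the two numbers measured so far, while compound 1 `COc1cc(-c2ccnc3cc(-c4ccc(C)cc4)nn23)cc(OC)c1OC` gives 21 nM. Compound 3 `COc1cc(-c2ccnc3cc(-c4ccc(-c5cnn(C)c5)cc4)nn23)cc(OC)c1OC` keeps the shared core and changes one group: 1-methyl-1H-pyrazol-4-yl in place of methoxy on an aromatic carbon. Within the data shown here, only one measured step involves this place, methoxy in place of methyl, and it was large: a 67-fold higher number from compound 1 to compound 2 (1.83 log units; beyond the scatter). Among the measured compounds shown here, that step shows the place is sensitive, but no measurement yet covers a group this big. A moderate move toward a lower number is therefore expected, a 4.7-fold lower number from compound 2 to compound 3 (0.67 log units; beyond the scatter), with wide uncertainty. For compound 3 the estimated value is 300 nM, within a range of 30 nM to 3000 nM.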

Compound 3, half-maximal inhibitory concentration: 1240 nM
Estimate against measurement, compound 3: 4.1-fold (0.62 log units) below; the measured number falls inside the stated range.
By their numbers in this assay, from the lowest: compound 1; then compounds 3 and 2 (each within the scatter of the next).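

In this assay, replacing methyl with 1-methyl-1H-pyrazol-4-yl gives a 59-fold higher number from compound 1 to compound 3 (1.77 log units; beyond the scatter), so a second group at this place also gives much weaker inhibition than methyl does. Replacing methoxy with the same group gives a 1.1-fold lower number from compound 2 to compound 3 (0.06 log units; within the scatter), so the two groups cannot be told apart here, even though the new one brings a five-membered aromatic ring. No measured evidence is available to explain why methyl stands apart from both. The compounds shown leave open whether chlorine, ethyl or an amine on this aromatic carbon would give a number close to that of compound 1, or whether methyl alone does so.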